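A few compounds are considered here, and "the series" means these few. Any claim that something is new, unique, unknown or untested is made for them only; others in the source may bear on it.

Measured so far in an assay on cells with melanin-concentrating hormone receptor 1 (Homo sapiens) as the target, read by radioligand binding; on this read-out lower numbers stand for stronger inhibition and higher numbers for weaker inhibition:
- compound 1 `CCCCCOc1cccc2ccc(N)nc12`: 580 nM
- compound 2 `CC(C)(C)CCOc1cccc2ccc(N)nc12`: 201 nM
- compound 3 `CCCC(C)Oc1cccc2ccc(N)nc12`: 105 nM

Compound 3 gives the lowest number of the three, but compound 2 sits near it, the gap being a 1.9-fold lower number from compound 2 to compound 3 (0.28 log units; within the scatter), so the two cannot be ranked against each other; only the gap to compound 1 is clear, at a 5.5-fold lower number from compound 1 to compound 3 (0.74 log units; beyond the scatter).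

Compound 4 `Nc1ccc2cccc(OCC3CCCO3)c2n1` is the next step: (oxolan-2-yl)methyl in place of 1-methylbutyl on an oxygen on an aromatic ring. The change keeps the side chain on the aromatic oxygen at about the same length but swaps an open, branched chain for one carrying a five-membered ring with one hetero atom and one hydrogen-bond acceptor.

Among the compounds with values here, the steps that bear on it are those in which the side chain itself was varied: a 2.9-fold lower number from compound 1 to compound 2 (0.46 log units; beyond the scatter) and a 5.5-fold lower number from compound 1 to compound 3 (0.74 log units; beyond the scatter), both modest, and a 1.9-fold lower number from compound 2 to compound 3 (0.28 log units; within the scatter), within the scatter. They show that the shape of the chain moves the number by a modest amount at most. None of them introduces a hetero atom into the chain, so that part of the change is unsupported by any measured pair.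

Compound 4 is therefore expected to land close to compounds 2 and 3, and the estimate is 250 nM with a range of 80 nM to 800 nM. This expected step, a 2.4-fold higher number from compound 3 to compound 4 (0.38 log units; beyond the scatter), is a mild weakening that may well fall within the scatter.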

Compound 4, half-maximal inhibitory concentration: > 2000 nM
Compound 4 was reported as a limit; the forecaster's own chance of this, stated with the estimate: 5%; middle value at least 8.0-fold (0.90 log units) from the limit.
By their numbers in this assay, from the lowest: compounds 3 and 2 (each within the scatter of the next); then compound 1. At a limit, above all of these: compound 4.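

In this assay compound 4 is recorded only as a limit and not as a number: the limit of > 2000 nM in this assay, at which 1 of the 4 values shown sits. Even so, the change at this oxygen on an aromatic ring reads clearly against all three open-chain compounds: an at least 19-fold higher number from compound 3 to compound 4 (1.27 log units; beyond the scatter), an at least 9.9-fold higher number from compound 2 to compound 4 (0.99 log units; beyond the scatter), and an at least 3.4-fold higher number from compound 1 to compound 4 (0.53 log units; beyond the scatter). Compound 4 therefore stands beyond the scatter from every earlier compound, including compound 1, so this position tolerates the shift from open carbon chains to (oxolan-2-yl)methyl far less well than the modest steps among those chains had shown.

The compounds shown do not separate the five-membered ring from its hetero atom, and cyclopentylmethyl, the same ring with carbon in place of the oxygen, would address that question directly. Also open, going by these compounds, are how far the true number of compound 4 lies beyond its limit and how an open chain carrying an ether oxygen, such as 2-methoxyethyl, or an amine would read on this oxygen.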